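Removing a fluoro from compound 1: expected binding shift

A few compounds are considered here, and "the series" means these few. Any claim that something is new, unique, unknown or untested is made for them only; others in the source may bear on it.

Measured so far in an assay on HEK293 cells for displacement of a labelled ligand from Melanocortin receptor 4 (Homo sapiens); a higher number here means a weaker inhibitor, a lower number a stronger inhibitor:
compound 1 `CC(C)[C@H](NC(=O)CCN(C)C)c1cccc(F)c1N1CCN(C(=O)[C@@H]2CN(C(C)C)C[C@H]2c2cc(F)ccc2F)CC1` gives 2050 nM
compound 2 `Cc1ccc(N2CCN(C(=O)[C@@H]3CNC[C@H]3c3ccc(Cl)cc3)CC2)c([C@@H](NC(=O)CCN(C)C)C(C)C)c1` gives 7.2 nM
compound 3 `CC(=O)N1C[C@@H](C(=O)N2CCN(c3ccc(C)cc3[C@@H](NC(=O)CCN(C)C)C(C)C)CC2)[C@H](c2ccc(Cl)cc2)C1` gives 7.6 nM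

Compound 1 stands highest of the three numbers; compound 3 is nearest and compound 2 furthest, both well beyond the scatter. Compound 4 `CC(C)[C@H](NC(=O)CCN(C)C)c1cccc(F)c1N1CCN(C(=O)[C@@H]2CN(C(C)C)C[C@H]2c2cccc(F)c2)CC1` differs from compound 1 by hydrogen in place of fluoro on an aromatic carbon. Among the compounds with values here, the only step between measured compounds, a 1.1-fold higher number from compound 2 to compound 3 (0.02 log units; within the scatter), concerns another group at another position, so no measured step bears on the loss of a fluoro; compound 2 and compound 3 differ from compound 1 in several places at once and give no single-change comparison. With nothing to anchor a direction, the expected step of a 1.0-fold lower number from compound 1 to compound 4 (0.01 log units; within the scatter) is none beyond the scatter. Compound 4 is therefore estimated at 2000 nM, with a range from 700 nM to 6000 nM.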

Compound 4, inhibition constant: 560 nM
Estimate against measurement, compound 4: 3.6-fold (0.55 log units) above; the measured number lies below the stated range.
By their numbers in this assay, from the lowest: compounds 2 and 3 (each within the scatter of the next); then compound 4; then compound 1.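

In this assay the change from 2,5-difluorophenyl to 3-fluorophenyl gives a 3.7-fold lower number from compound 1 to compound 4 (0.56 log units; beyond the scatter) and so lies beyond the scatter, unlike the acetyl change in a 1.1-fold higher number from compound 2 to compound 3 (0.02 log units; within the scatter) on the ring amine nitrogen. The number therefore responds to the fluoro on this aromatic carbon, ortho to a large group, though only modestly and in this single pair. Nothing shown accounts for the shift.

Open, from the compounds shown here alone, is whether chloro, methyl or methoxy at this position would move the number further, and whether the same loss of fluoro gives a similar step on compound 2.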